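This account rests on a few compounds, and the source may have more. Where it says the series, first, only, none or still open, it means among the compounds named here.

Three compounds sharing one core, and differing only in the aromatic group on an amide-type nitrogen, have been measured. In a functional assay on MDA-MB-231 cells (Homo sapiens) for cytotoxicity, read by MTT assay, with a stated time of 48 h (on this read-out lower numbers stand for stronger inhibition and higher numbers for weaker inhibition), compound 1 `O=C(NCCCCC(c1ccc(F)cc1)c1ccc(F)cc1)Nc1ccc([N+](=O)[O-])cc1` gives 6470 nM, compound 2 `O=C(NCCCCC(c1ccc(F)cc1)c1ccc(F)cc1)Nc1ccc(Cl)c(C(F)(F)F)c1` gives 3150 nM and compound 3 `O=C(NCCCCC(c1ccc(F)cc1)c1ccc(F)cc1)Nc1ccc(Cl)c([N+](=O)[O-])c1` gives 4060 nM. The value of compound 3 lies inside the span of the other two and within the usual scatter of each.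

Compound 4 `O=C(NCCCCC(c1ccc(F)cc1)c1ccc(F)cc1)Nc1ccc([N+](=O)[O-])c(Cl)c1` has not yet been measured. It holds the same atoms as compound 3, joined differently: 3-chloro-4-nitrophenyl in place of 4-chloro-3-nitrophenyl on an amide-type nitrogen. In words, 3-chloro-4-nitrophenyl stands in place of 4-chloro-3-nitrophenyl on an amide-type nitrogen.

Going by the values given here, no measured pair shows this exact swap, so the evidence is indirect. Changing the aromatic group has so far moved the number only a little. The steps of a 1.6-fold lower number from compound 1 to compound 3 (0.20 log units; within the scatter) and a 1.3-fold higher number from compound 2 to compound 3 (0.11 log units; within the scatter) both stay within the scatter, and the largest, a 2.1-fold lower number from compound 1 to compound 2 (0.31 log units; beyond the scatter), is modest. On that basis, no change beyond the scatter is expected in this assay, and the estimated step is a 1.1-fold higher number from compound 3 to compound 4 (0.04 log units; within the scatter).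

For compound 4 the expected value is 4500 nM, with an estimated range from 2400 nM to 8000 nM.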

Compound 4, half-maximal inhibitory concentration: 3470 nM
Compound 4: the middle estimate sits 1.3-fold (0.11 log units) above what was measured; low and high end bracket the measured number.
By their numbers in this assay, from the lowest: compounds 2, 4, 3 and 1 (each within the scatter of the next, the first and the last beyond it).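

Exchanging 4-chloro-3-nitrophenyl for 3-chloro-4-nitrophenyl on the amide-type nitrogen gives a 1.2-fold lower number from compound 3 to compound 4 (0.07 log units; within the scatter) in this assay, so this direct test of rearranging the same atoms shows no change that can be told apart from the scatter. This pair also gives the first single-place view of chloro in place of hydrogen on an aromatic carbon of the 4-nitrophenyl group, with a 1.9-fold lower number from compound 1 to compound 4 (0.27 log units; within the scatter), which is close to the edge of the scatter but still inside it, while the comparison with the chloro and trifluoromethyl group gives a 1.1-fold higher number from compound 2 to compound 4 (0.04 log units; within the scatter). No separate measurement is available to explain why these aromatic groups give such similar numbers.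

From the compounds shown here alone, all four compounds carry a nitro, chloro or trifluoromethyl group on the aromatic ring, so it remains open whether an amine or a carboxylic acid there would move the number further than these steps do. The shared core also stays fixed throughout, which leaves open what a longer chain, or a different group in place of either 4-fluorophenyl ring, would do in this cell assay.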